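Amino for Hydrogen on a Shared Core: Expected Cytotoxicity

The source may report more compounds than this note shows. Statements on the series, on what has been measured and on what is new or still open speak of the compounds shown alone.

Measured compounds:
compound 1 `ClCc1ccc(Cn2cnc3c(Cl)ncnc32)cc1`, 70800 nM
compound 2 `Nc1nc(Cl)c2ncn(Cc3ccc(CCl)cc3)c2n1`, 46800 nM
compound 3 `ClCc1ccccc1Cn1cnc2c(Cl)ncnc21`, 55000 nM

In a functional assay on SF-539 cells (Homo sapiens) for cytotoxicity, read by sulforhodamine B assay, with a stated time of 48 h (on this read-out lower numbers stand for higher toxicity in this test and higher numbers for lower toxicity in this test), compound 1 gives 70800 nM, compound 2 gives 46800 nM and compound 3 gives 55000 nM. Compound 2 is obtained from compound 1 by one change, (amino in place of hydrogen on an aromatic carbon), and the step is a 1.5-fold lower number from compound 1 to compound 2 (0.18 log units; within the scatter). Compound 3 carries the same atoms as compound 1 joined differently; the difference between the two cores is not broken down here, and their two values in this assay lie within the scatter of each other.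

Compound 4 `Nc1nc(Cl)c2ncn(Cc3ccccc3CCl)c2n1` has not yet been measured. It differs from compound 3 by amino in place of hydrogen on an aromatic carbon, the same change as from compound 1 to compound 2, at a place described in identical words in both cases. Because the earlier step was a 1.5-fold lower number from compound 1 to compound 2 (0.18 log units; within the scatter), the step from compound 3 to compound 4 is expected to be of like size, a 1.4-fold lower number from compound 3 to compound 4 (0.14 log units; within the scatter). On that basis compound 4 is estimated at 40000 nM in this assay, with a range from 20000 nM to 80000 nM.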

Compound 4, concentration lethal to 50% of the cells: 81300 nM
Compound 4: the middle estimate sits 2.0-fold (0.31 log units) below what was measured; the whole stated range lies below it.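

In this assay, amino in place of hydrogen on an aromatic carbon of the core of compound 3 gives a 1.5-fold higher number from compound 3 to compound 4 (0.17 log units; within the scatter). Although this step and the earlier one run in opposite directions, each lies within the scatter and they do not differ from each other beyond it: the same change on two cores in this assay, a 1.5-fold lower number (0.18 log units; within the scatter) from compound 1 to compound 2 and a 1.5-fold higher number (0.17 log units; within the scatter) from compound 3 to compound 4, 2.2-fold (0.35 log units) apart, within the scatter of two such steps. Going by these compounds alone, this shows that on both cores the change leaves the number within the usual spread of repeated measurements, but with only two pairs in a single assay it does not show that the change has any real effect to carry over, nor that the two cores respond differently.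

The compounds shown leave open whether another group at the same carbon between two ring nitrogen atoms, such as a dimethylamino or a methoxy group, would give a step beyond the scatter in this assay. They also leave open whether the amino step would stay within the scatter on a core bearing a longer chain in place of the chloromethyl group.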